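The source may report more compounds than this note shows. Statements on the series, on what has been measured and on what is new or still open speak of the compounds shown alone.

Measured so far:
compound 1 `CCOCCOc1cccc2ccc(N)nc12` — > 2000 nM
compound 2 `CC(CC(C)(C)C)Oc1cccc2ccc(N3CCCC3)nc12` — > 2000 nM

Both numbers come from an assay on cells with melanin-concentrating hormone receptor 1 (Homo sapiens) as the target, read by radioligand binding; a lower number here means a stronger inhibitor, a higher number a weaker inhibitor. For compound 1 the result in this assay is not a number but a limit of the assay, > 2000 nM. For compound 2 the result is likewise only a limit, > 2000 nM. So compound 2 stands at the edge of what this assay can report, and it stands there with the other value as well: the limit of > 2000 nM in this assay, at which 2 of the 2 values shown sit. For the measured compounds named here, no pair of measured compounds differs in just one place, so no measured step is available to lean on.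

Compound 3 `CC(CC(C)(C)C)Oc1cccc2ccc(N(C)C)nc12` is the compound not yet measured. It differs from compound 2 in one place: dimethylamino in place of pyrrolidin-1-yl on an aromatic carbon. The group that leaves and the group that enters are both amines without a hydrogen-bond donor, and the enters group is the smaller of the two.

With compound 2 giving only a limit, the step from compound 2 to compound 3 is expected to stay within the scatter or to land on a limit again, a step that the limit leaves unreadable from compound 2 to compound 3. Compound 3 is estimated at 3000 nM in this assay, with a range from 800 nM to 12000 nM.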

Compound 3, half-maximal inhibitory concentration: > 2000 nM
Compound 3 was reported as a limit; the forecaster's own chance of this, stated with the estimate: 70%; the middle value does not contradict the limit.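

For the compounds shown here, compound 2 and compound 3 both sit at a limit of this assay rather than at a number, so the change from pyrrolidin-1-yl to dimethylamino gives no step that can be read. The compounds shown leave open how strongly any of them acts and which change would give a true number, as all stay at one limit: the limit of > 2000 nM in this assay, at which 3 of the 3 values shown sit.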